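The compounds below may be only part of what the source reports. "The series", "measured", "known", "first", "only" and "open" are said of these compounds alone.

Among the compounds with values here, compound 3 `CCC(C)C(NC(=O)n1nnc2ccccc21)C(=O)NC1CCCCC1` is one of three compounds tested so far in a functional assay on WI-38 cells (Homo sapiens) for inhibition; a higher number here means a weaker inhibitor, a lower number a stronger inhibitor. In this assay compound 3 gives only a limit, > 100000 nM. Compound 1 `CCC(C)C1NC(=O)N(C2CCCC2)C1=O` likewise returns only a limit in this assay, namely > 100000 nM. Compound 2 `CC(C)C(NC(=O)NO)C(=O)NC1CCCC1` also reaches no number in this assay, giving the limit > 100000 nM. All three results therefore sit at the same point, (the limit of > 100000 nM in this assay, at which 3 of the 3 values shown sit), and none of them yields a number from which the size of a step could be read. Within the data shown here, no two of the measured compounds differ in a single place, so no measured step is available.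

Compound 4 `CCC(C)C(NC(=O)n1nnc2ccccc21)C(=O)NCc1ccccc1` has not yet been measured in this assay. It differs from compound 3 by benzyl in place of cyclohexyl on an amide-type nitrogen, the other neighbour of which is a carbonyl carbon; cut one bond further out, the exchange reads cyclohexylamino to benzylamino.

Because compound 3 sits at the limit > 100000 nM, there is no number to move from, and the step from compound 3 to compound 4 is expected to be a number no higher from compound 3 to compound 4 (the limit leaves the size open), that is, none beyond the scatter. For compound 4 the expected result in this assay is 100000 nM, with a range from 30000 nM to 300000 nM, and most likely again only a limit.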

Compound 4, half-maximal inhibitory concentration: > 100000 nM
Compound 4 gave a limit, no number; the forecaster's own chance of this, stated with the estimate: 85%; the middle value sits exactly at the limit.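

Within the data shown here, compound 3 and compound 4 each return only a limit in this assay, so no step between them can be read, and the whole set stands at one point: the limit of > 100000 nM in this assay, at which 4 of the 4 values shown sit.

The compounds shown leave open how strongly any of them inhibits in this assay, and whether benzyl in place of cyclohexyl on an amide-type nitrogen changes that at all.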